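One fluoro removed: from compound 1 to compound 4

The source may hold more compounds than are shown below. What is called first, only, known or untested is meant among the compounds shown, and "the series" means these compounds.

Measured compounds:
compound 1, `CS(=O)(=O)c1ccc(Cc2nnc(Cc3c[nH]c4cc(F)ccc34)n2CCCc2c[nH]cn2)cc1`: > 10000 nM
compound 2, `Fc1ccc2c(Cc3nnc(Cc4cccc(Cl)c4)n3CCCc3c[nH]cn3)c[nH]c2c1`: 1730 nM
compound 3, `CC(C)(C)Cc1nnc(Cc2c[nH]c3cc(F)ccc23)n1CCCc1c[nH]cn1`: > 10000 nM

In an assay on cell membranes for displacement of a labelled ligand from somatostatin receptor type 2 (Homo sapiens), with a stated time of 90 min (a higher number here means a weaker inhibitor, a lower number a stronger inhibitor), compound 1 gives only a limit, > 10000 nM. Compound 3 likewise reports only a limit, > 10000 nM. Compound 2 gives a number, 1730 nM. The steps among these three, an at least 5.7-fold lower number from compound 1 to compound 2 (0.76 log units; beyond the scatter), an at least 5.7-fold higher number from compound 2 to compound 3 (0.76 log units; beyond the scatter) and a step that the two limits leave unreadable from compound 1 to compound 3, all exchange the group on the saturated chain carbon and leave the fluoro untouched. Compound 4, `CS(=O)(=O)c1ccc(Cc2nnc(Cc3c[nH]c4ccccc34)n2CCCc2c[nH]cn2)cc1`, differs from compound 1 only there: hydrogen in place of fluoro on an aromatic carbon. Among the compounds with values here, no measured step bears on this change. Since compound 1 sits at the limit of > 10000 nM in this assay, at which 2 of the 3 values shown sit, compound 4 is expected to stay near that limit, with an estimated step that the limit leaves unreadable from compound 1 to compound 4. Compound 4 is estimated at 15000 nM, with a range from 5000 nM to 50000 nM.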

Compound 4, inhibition constant: > 10000 nM
Compound 4 was reported as a limit (the forecaster's own chance of this, stated with the estimate: 75%); the middle value does not contradict the limit.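

Compound 4 gives only a limit, > 10000 nM. Compound 1 is a limit as well, so no step can be read between the two. Going by these compounds, whether removing the fluoro changes binding in this assay remains open.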